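Swapping a Benzyl Ether for a Dichlorophenyl Ether

The compounds below may be only part of what the source reports. "The series", "measured", "known", "first", "only" and "open" are said of these compounds alone.

Going by the values given here, compound 1 `Cc1ccccc1COc1ccc(N2CCC[C@H]2CC(=O)O)cc1` is the only compound here with a numerical result: in a functional assay on cells for agonist activity at Free fatty acid receptor 1 (Mus musculus), read by FLIPR and calcium flux, with a stated time of 100 s (on this read-out lower numbers stand for an effect already at smaller amounts and higher numbers for an effect only at larger amounts of compound), compound 1 gives 3400 nM. Compound 2 `Cc1ccccc1COc1ccc(N2CCC[C@H]2CC(=O)O)cc1C` carries a methyl in place of hydrogen on an aromatic carbon of the shared core. In this assay compound 2 reaches only a limit, > 33000 nM, and the measurement stops there (the limit of > 33000 nM in this assay, at which 1 of the 2 values shown sits). The step of an at least 9.7-fold higher number from compound 1 to compound 2 (0.98 log units; beyond the scatter) shows that even a small addition to the core can cost activity. Compound 3 `O=C(O)C[C@@H]1CCCN1c1ccc(Oc2ccc(Cl)cc2Cl)cc1` differs from compound 1 in a different place: 2,4-dichlorophenyl in place of 2-methylbenzyl on an oxygen on an aromatic ring. Among the compounds with values here, no measured step touches this ether side of the molecule; the single step known concerns the core, so it bears on compound 3 only as a sign that the one change tried so far lowered activity. Compound 3 is therefore expected to come out somewhat weaker, a step estimated as a 2.1-fold higher number from compound 1 to compound 3 (0.31 log units; beyond the scatter). Compound 3 is estimated at 7000 nM, between 1500 nM and 30000 nM.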

Compound 3, half-maximal effective concentration: 3200 nM
For compound 3 the middle estimate is 2.2-fold (0.34 log units) above the measured one; the measured number falls inside the stated range.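

In this assay, putting 2,4-dichlorophenyl in place of 2-methylbenzyl gives a 1.1-fold lower number from compound 1 to compound 3 (0.03 log units; within the scatter), so this read-out does not separate the two compounds. Going by these compounds alone, the only earlier step, on the shared core, cost activity, whereas this one shows that a group on the oxygen on an aromatic ring can be exchanged with no change beyond the scatter, at least when both groups have 8 heavy atoms and one six-membered aromatic ring of carbon only. Nothing given here explains why these two groups perform alike.

On these data alone, it remains open whether the same oxygen would accept a quite different group, such as one carrying an amine, or a longer chain. Also open, as far as these compounds go, is what each of the two chlorines contributes on its own.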